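Hydroxycyclohexyl for cyclopentyl on the ring nitrogen

A few compounds are considered here, and "the series" means these few. Any claim that something is new, unique, unknown or untested is made for them only; others in the source may bear on it.

Measured compounds:
compound 1, `CN1CCN(c2ccc(Nc3ncc4nc(Sc5ccccc5)n(C5CCOCC5)c4n3)cc2)CC1`: in an assay on isolated protein for inhibition of Receptor tyrosine-protein kinase erbB-3 variant L858R (Homo sapiens), read by luminescence and Kinase-Glo, with a stated time of 40 min (a higher number here means a weaker inhibitor, a lower number a stronger inhibitor), compound 1 gives 2 nM
compound 2, `CN1CCN(c2ccc(Nc3ncc4nc(Sc5ccccc5)n(C5CCCC5)c4n3)cc2)CC1`: in this assay compound 2 gives 4.2 nM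
compound 3, `CN1CCN(c2ccc(Nc3ncc4nc([S+]([O-])c5ccccc5)n(C5CCCC5)c4n3)cc2)CC1`: in this assay compound 3 gives 4.2 nM

Compound 2 stands level with compound 3, the two sharing the highest number of the three, with no change at the digits printed from compound 2 to compound 3 (within the scatter). Compound 1 sits lowest, with a 2.1-fold higher number from compound 1 to compound 2 (0.32 log units; beyond the scatter).

Compound 4, `CN1CCN(c2ccc(Nc3ncc4nc(Sc5ccccc5)n([C@H]5CC[C@H](O)CC5)c4n3)cc2)CC1`, differs from compound 2 by 4-hydroxycyclohexyl in place of cyclopentyl on an aromatic nitrogen. Of the measured steps only one bears on this place: a 2.1-fold higher number from compound 1 to compound 2 (0.32 log units; beyond the scatter), where a six-membered ring carrying an oxygen gave the lower number and cyclopentyl the higher one. The step of no change at the digits printed from compound 2 to compound 3 (within the scatter) touches the phenylsulfanyl side and says nothing about this ring. The entering 4-hydroxycyclohexyl again brings a six-membered ring with an oxygen, so compound 4 is expected to move back toward compound 1 by a modest step, a 1.7-fold lower number from compound 2 to compound 4 (0.23 log units; within the scatter), or to stay within the scatter of compound 2. Compound 4 is estimated at 2.5 nM, within 1 nM to 7 nM.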

Compound 4, half-maximal inhibitory concentration: 2.4 nM
Beside the measured number, compound 4's estimate is 1.0-fold (0.02 log units) above it; low and high end bracket the measured number.
By their numbers in this assay, from the lowest: compounds 1, 4, 2 and 3 (each within the scatter of the next, the first and the last beyond it).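

The swap of cyclopentyl for 4-hydroxycyclohexyl gives a 1.8-fold lower number from compound 2 to compound 4 (0.24 log units; within the scatter), and the swap of oxan-4-yl for 4-hydroxycyclohexyl gives a 1.2-fold higher number from compound 1 to compound 4 (0.08 log units; within the scatter), so in this assay compound 4 cannot be told apart from either compound. The position on the aromatic nitrogen therefore also accepts a group with a hydrogen-bond donor and two defined stereocentres, with the number staying within the scatter of both earlier groups. Nothing available explains the numbers at this position.

The compounds shown leave open what the hydroxyl itself contributes, since plain cyclohexyl does not appear among them, nor does the other stereoisomer of 4-hydroxycyclohexyl. They also leave open how a 4-aminocyclohexyl group or a piperidin-4-yl ring would read at this position.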